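From a Cyanoethoxy Ester Chain to a Methylamino Amide

The source may hold more compounds than are shown below. What is called first, only, known or untested is meant among the compounds shown, and "the series" means these compounds.

Three compounds have been measured in an ADME assay on liver (Homo sapiens) for metabolic stability, read by LC-MS, using S9 fraction and NADPH, with a stated time of 45 min, tested at 1 uM; on this read-out lower numbers stand for a shorter-lived compound and higher numbers for a longer-lived compound:
compound 1 `COCCOC(=O)c1cc(N)c(Nc2ccc(C#N)cc2)cc1Oc1c(C)cc(/C=C/C#N)cc1C` gives 0.158 h
compound 2 `Cc1cc(/C=C/C#N)cc(C)c1Oc1cc(Nc2ccc(C#N)cc2)c(N)cc1C(=O)N1CC1` gives 1.83 h
compound 3 `Cc1cc(/C=C/C#N)cc(C)c1Oc1cc(Nc2ccc(C#N)cc2)c(N)cc1C(=O)OCCC#N` gives 0.2 h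

Compound 3 stands second highest of the three, close to compound 1 and well below compound 2. Compound 4 `CNC(=O)c1cc(N)c(Nc2ccc(C#N)cc2)cc1Oc1c(C)cc(/C=C/C#N)cc1C` differs from compound 3 by methylamino in place of 2-cyanoethoxy on a carbonyl carbon. Two measured steps also exchange the group on this carbonyl carbon and bear on it: a 12-fold higher number from compound 1 to compound 2 (1.06 log units; beyond the scatter) and a 9.2-fold lower number from compound 2 to compound 3 (0.96 log units; beyond the scatter). Both lie beyond the scatter, and both show the aziridin-1-yl compound far longer-lived than either chain-bearing one. Methylamino is not aziridin-1-yl, so the size is uncertain, but a rise beyond the scatter is expected. Compound 4 is therefore estimated at 1.2 h, between 0.4 h and 3.5 h, which means an expected step of a 6.0-fold higher number from compound 3 to compound 4 (0.78 log units; beyond the scatter).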

Compound 4, half-life: 1.6 h
Estimate against measurement, compound 4: 1.3-fold (0.12 log units) below; the range from low to high includes it.
By their numbers in this assay, from the lowest: compounds 1 and 3 (each within the scatter of the next); then compounds 4 and 2 (each within the scatter of the next).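

In this assay, a long half-life is not limited to aziridin-1-yl on this carbonyl carbon: the open-chain methylamino group gives an 8.0-fold higher number from compound 3 to compound 4 (0.90 log units; beyond the scatter) and a 10-fold higher number from compound 1 to compound 4 (1.01 log units; beyond the scatter), while a 1.1-fold lower number from compound 2 to compound 4 (0.06 log units; within the scatter) leaves the two nitrogen-linked groups indistinguishable. Among these four compounds, both groups attached through nitrogen therefore sit well above both chains attached through oxygen. No measurement shown explains this difference. From the compounds shown here alone, it remains open how dimethylamino or a longer chain on the amide nitrogen would fare on this carbonyl carbon.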